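Swapping benzoyl for ethyl on an amine nitrogen

The source may hold more compounds than are shown below. What is called first, only, known or untested is meant among the compounds shown, and "the series" means these compounds.

Measured in a functional assay on HL-60 cells (Homo sapiens) for cytotoxicity, read by MTT assay, with a stated time of 96 h; on this read-out higher numbers stand for weaker inhibition and lower numbers for stronger inhibition:
- Compound 1 `CC[C@H](N)C(=O)N[C@@H]1C(=O)N2[C@@H](CC[C@@H]1CCNC(=O)c1ccccc1)CC[C@H]2C(=O)NC(c1ccccc1)c1ccccc1`: 50700 nM
- Compound 2 `CC[C@H](NC)C(=O)N[C@@H]1C(=O)N2[C@@H](CC[C@@H]1CCNC(=O)c1ccccc1)CC[C@H]2C(=O)NC(c1ccccc1)c1ccccc1`: 32600 nM

Going by the values given here, compound 2 gives 32600 nM, within the scatter of its only neighbour, compound 1. Compound 3 `CCNCC[C@H]1CC[C@H]2CC[C@@H](C(=O)NC(c3ccccc3)c3ccccc3)N2C(=O)[C@H]1NC(=O)[C@H](CC)NC` differs from it in one place: ethyl in place of benzoyl on an amine nitrogen. Among the compounds with values here, the only measured step, a 1.6-fold lower number from compound 1 to compound 2 (0.19 log units; within the scatter), put methyl in place of hydrogen on a different amine nitrogen, so no measurement covers this swap directly. With nothing to set a direction, the expected step in this assay is a 1.2-fold higher number from compound 2 to compound 3 (0.09 log units; within the scatter), no step beyond the scatter. Compound 3 is estimated at 40000 nM, with an expected range of 12000 nM to 100000 nM.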

Compound 3, half-maximal inhibitory concentration: 76400 nM
Compound 3: middle estimate off by 1.9-fold (0.28 log units), on the low side, within the range that was stated.
By their numbers in this assay, from the lowest: compounds 2, 1 and 3 (each within the scatter of the next, the first and the last beyond it).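

In this assay ethyl in place of benzoyl on this amine nitrogen gives a 2.3-fold higher number from compound 2 to compound 3 (0.37 log units; beyond the scatter) and so moves the number modestly upward, whereas the earlier methyl change on a different amine nitrogen stayed within the scatter. This nitrogen is therefore the first place in the series where a single change shows beyond the scatter, though only just. Nothing available gives a cause for this step.

Still open, on these data alone, is where an acetyl group or a plain amine on this nitrogen would fall. Also open, as far as these compounds go, is whether the carbonyl or the aromatic ring of benzoyl counts for more.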